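Butyl Extension on the Methylseleno Group of Compound 1

The source may hold more compounds than are shown below. What is called first, only, known or untested is meant among the compounds shown, and "the series" means these compounds.

Within the data shown here, compound 1 `C[Se]c1nc(N)c2ccccc2n1` is the weakest grower inhibitor of the three measured members: in a functional assay on CCRF-CEM cells (Homo sapiens) for cytotoxicity, read by MTT assay, with a stated time of 72 h (on this read-out higher numbers stand for weaker inhibition of growth and lower numbers for stronger inhibition of growth), compound 1 gives 65100 nM, the highest number in the set. Compound 3 `C[Se]c1nc([Se]C)c2ccccc2n1` gives 31200 nM and compound 2 `Nc1nc([SeH])nc2ncccc12` gives 30900 nM; the values of compound 2 and compound 3 lie close to each other, and compound 1 stands apart from both.

Among the measured compounds shown here, the only one-place step among the measured compounds is a 2.1-fold lower number from compound 1 to compound 3 (0.32 log units; beyond the scatter), where a methylseleno group replaces the amino group on the core of compound 1. It does not touch the chain on the selenium, so it bears on compound 4 only in showing that changes at this part of the core move the number modestly.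

Compound 4 `CCCCC[Se]c1nc(N)c2ccccc2n1` differs from compound 1 by butyl in place of hydrogen on a saturated chain carbon bound to a selenium atom. For the measured compounds named here, no measured step changes the length of this chain, so there is no direct precedent. The expectation for compound 4 is therefore a step of a 1.6-fold lower number from compound 1 to compound 4 (0.21 log units; within the scatter), with wide uncertainty on either side. Compound 4 is estimated at 40000 nM in this assay, within a range from 10000 nM to 150000 nM.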

Compound 4, concentration for 50% growth inhibition: 34800 nM
Compound 4: middle estimate off by 1.1-fold (0.06 log units), on the high side; low and high end bracket the measured number.
By their numbers in this assay, from the lowest: compounds 2, 3, 4 and 1 (each within the scatter of the next, the first and the last beyond it).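

Among these compounds, with only one chain length on the selenium in the earlier compounds, the chain itself had not been varied, and the single earlier step concerned the amino group on the core. In this assay, among the compounds shown here, the first change at the chain, butyl in place of hydrogen on a saturated chain carbon bound to a selenium atom, gives a 1.9-fold lower number from compound 1 to compound 4 (0.27 log units; within the scatter) and so leaves the number within the usual scatter of compound 1 even though the same difference reads as methyl to pentyl. At this position the added carbon chain therefore has no effect that can be told apart from repeat-measurement noise in this growth read-out, and no supporting data offer an explanation for this result.

On these data alone, two chain lengths cannot define a trend, so it remains open whether a longer chain such as decyl, a branched chain such as isopropyl, a benzyl group, or a chain ending in a carboxylic acid or an amine would move the number beyond the scatter. As far as these compounds go, it is also open whether pentyl in place of methyl would give a comparable step on the selenium groups of compound 3.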